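Swapping the five-membered ring in a nitrile-bearing amide

The source may hold more compounds than are shown below. What is called first, only, known or untested is meant among the compounds shown, and "the series" means these compounds.

Measured compounds:
Compound 1, `N#C/C(=C\c1c(F)c(F)c(F)c(F)c1F)C(=O)c1c[nH]c2ccccc12`, gives 13000 nM in a functional assay on MCF7 cells (Homo sapiens) for inhibition, read by MTT assay, with a stated time of 72 h; a higher number here means a weaker inhibitor of growth, a lower number a stronger inhibitor of growth.
Compound 2, `N#C/C(=C\c1ccc[nH]1)C(=O)NCc1ccc(Cl)c(Cl)c1`, gives 6000 nM in this assay.

Of the compounds shown here, two have been measured so far, and compound 2 gives the lowest of the two numbers. Its nearest neighbour is compound 1, whose number is higher by an amount that lies beyond the usual scatter of repeated measurements. The two structures differ in several places at once, so only their two values can be compared, not a single change.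

Compound 3, `N#C/C(=C\c1ccco1)C(=O)NCc1ccc(Cl)c(Cl)c1`, has not yet been measured. It differs from compound 2 in one place: furan-2-yl in place of 1H-pyrrol-2-yl on a double-bonded chain carbon bound to a double-bonded chain carbon. Among the measured compounds shown here, no measured pair shows what this swap does here, so the expectation rests on compound 2 alone. The change is small in size and keeps the ring shape, so a step of modest size is expected in this assay, most likely toward a somewhat higher number, though a result within the scatter would not surprise. Compound 3 is therefore estimated at 8000 nM, with a range from 3000 nM to 25000 nM, which means an expected step of a 1.3-fold higher number from compound 2 to compound 3 (0.12 log units; within the scatter).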

Compound 3, concentration for 50% growth inhibition: 20000 nM
Estimate against measurement, compound 3: 2.5-fold (0.40 log units) below; low and high end bracket the measured number.
By their numbers in this assay, from the lowest: compound 2; then compounds 1 and 3 (each within the scatter of the next).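

In this assay, putting furan-2-yl in place of 1H-pyrrol-2-yl on a double-bonded chain carbon bound to a double-bonded chain carbon gives a 3.3-fold higher number from compound 2 to compound 3 (0.52 log units; beyond the scatter), so the choice of ring at this position matters for growth inhibition, and compound 2 is the stronger inhibitor of this pair. The two rings have the same size and the same count of heavy atoms, yet exchanging the ring nitrogen for oxygen, which also takes the count from 1 hydrogen-bond donor and 0 acceptors to 0 donors and 1 acceptor, is enough to produce a step beyond the scatter. Nothing measured here separates the loss of the donor from the change of atom itself, and no available data explain the step.

This single pair leaves open how other rings would behave at this position, such as thiophen-2-yl, with sulfur as the ring atom, or 1-methyl-1H-pyrrol-2-yl, with a methyl group in place of the hydrogen on the ring nitrogen. It also leaves open whether the same swap would give a step of similar size with a different group on the amide nitrogen.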